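The source may report more compounds than this note shows. Statements on the series, on what has been measured and on what is new or still open speak of the compounds shown alone.

Working notes on the series. Compound 3 `C=CCn1c(=O)/c(=C\c2ccc(F)c(Br)c2)[nH]c(=O)/c1=C\c1ccccc1OC` is reported as "not active" (no number reported) in a functional assay on HL-60 cells (Homo sapiens) for cytotoxicity, read by CCK-8 assay, with a stated time of 72 h; a higher number here means a weaker inhibitor, a lower number a stronger inhibitor; it returned no number, so it stands outside the measured range of the set. The two compounds with numbers share its core: compound 1 `C=CCn1c(=O)/c(=C\c2cccc(F)c2)[nH]c(=O)/c1=C\c1ccccc1OC` gives 8890 nM in this assay, and compound 2 `C=CCn1c(=O)/c(=C\c2ccccc2C(F)(F)F)[nH]c(=O)/c1=C\c1ccccc1OC` gives 4600 nM in this assay. Among the compounds with values here, the only step between measured compounds that differ in one place is a 1.9-fold lower number from compound 1 to compound 2 (0.29 log units; within the scatter), an exchange of the aryl group on the same double-bonded chain carbon, and it stays within the scatter. Compound 4 `C=CCn1c(=O)/c(=C\c2cccc(C)c2)[nH]c(=O)/c1=C\c1ccccc1OC` differs from compound 3 by 3-methylphenyl in place of 3-bromo-4-fluorophenyl on a double-bonded chain carbon bound to an aromatic carbon. Within the data shown here, no measured step bears directly on an exchange of this kind, and compound 3 itself offers no number to step from; the only guide is that compound 1 and compound 2 both lie in the same weak region of this assay without a shift beyond the scatter between them. Compound 4 is therefore expected to land near that region rather than to repeat the inactive result of compound 3, though a reported limit remains possible. The estimate for compound 4 in this assay is 10000 nM, with a range from 3000 nM to 40000 nM.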

Compound 4, half-maximal inhibitory concentration: 16700 nM
Compound 4: middle estimate off by 1.7-fold (0.22 log units), on the low side; low and high end bracket the measured number.
By their numbers in this assay, from the lowest: compounds 2, 1 and 4 (each within the scatter of the next, the first and the last beyond it).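

In this assay, the exchange of the aryl group on the double-bonded chain carbon now gives a step beyond the scatter among the compounds with numbers: 3-methylphenyl in place of 2-(trifluoromethyl)phenyl gives a 3.6-fold higher number from compound 2 to compound 4 (0.56 log units; beyond the scatter) as a modest shift. Methyl in place of fluoro on an aromatic carbon gives a 1.9-fold higher number from compound 1 to compound 4 (0.27 log units; within the scatter) and so does not separate these two compounds, while compound 4, unlike compound 3, returns a number. No measured property is at hand to account for either step.

Open, on these data alone, is whether the bromo or the fluoro of 3-bromo-4-fluorophenyl goes with the inactive result of compound 3. Also open, as far as these compounds go, is whether an amine or a carboxylic acid on this aryl group would move the number out of this weak region.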